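The source may hold more compounds than are shown below. What is called first, only, known or untested is meant among the compounds shown, and "the series" means these compounds.

Compound 1 `CCCC(=O)C1=C(C)NC(=O)NC1c1ccco1` and compound 2 `CCCC(=O)C1=C(C)NC(=O)NC1c1ccoc1` were both tested in an assay on membranes from HeLa cells for displacement of a labelled ligand from adenosine receptor A3 (Homo sapiens), read by scintillation counting, with a stated time of 180 min, tested at 1 uM; on this read-out lower numbers stand for less inhibition and higher numbers for more inhibition at the one concentration tested (going by the name of the read-out). Compound 1 gives 1% and compound 2 gives 2%, so the change furan-3-yl in place of furan-2-yl on a saturated ring carbon produced a number 1 percentage points higher from compound 1 to compound 2 (within the scatter). Compound 3 `CCC(CC)OC(=O)C1=C(C)NC(=O)NC1c1ccco1` shares the core of compound 1 but carries the change ((pentan-3-yl)oxy in place of propyl on a carbonyl carbon); in this assay compound 3 gives 1%, which is no change at the digits printed from compound 1 to compound 3 (within the scatter). Compound 4 `CCC(CC)OC(=O)C1=C(C)NC(=O)NC1c1ccoc1` has not been measured. Going by the values given here, it differs from compound 3 by furan-3-yl in place of furan-2-yl on a saturated ring carbon, the same kind of change as the one from compound 1 to compound 2, though the surroundings are not identical: in compound 1 the saturated ring carbon is next to the ring atom that bears a propylcarbonyl group, while in compound 3 it is next to the ring atom that bears a group of 8 heavy atoms. Because the earlier step was a number 1 percentage points higher from compound 1 to compound 2 (within the scatter), the step from compound 3 to compound 4 is expected to be a number 1 percentage points higher from compound 3 to compound 4 (within the scatter). Compound 4 is therefore estimated at 2% in this assay, within a range from -5% to 9%.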

Compound 4, a percentage reported as inhibition, at one concentration (the size of the read-out at that concentration, not a potency): 5%
For compound 4 the middle estimate is 3 percentage points below the measured one, within the range that was stated.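

In this assay, furan-3-yl in place of furan-2-yl on a saturated ring carbon gave a number 4 percentage points higher from compound 3 to compound 4 (within the scatter), and this step agrees with the earlier one on the core of compound 1: the same change on two cores in this assay, a number 1 percentage points higher (within the scatter) from compound 1 to compound 2 and a number 4 percentage points higher (within the scatter) from compound 3 to compound 4, 3 percentage points apart, within the scatter of two such steps. Likewise, (pentan-3-yl)oxy in place of propyl on a carbonyl carbon gave a number 3 percentage points higher from compound 2 to compound 4 (within the scatter), which agrees with the same change on the furan-2-yl compounds: the same change on two cores in this assay, no change at the digits printed (within the scatter) from compound 1 to compound 3 and a number 3 percentage points higher (within the scatter) from compound 2 to compound 4, 3 percentage points apart, within the scatter of two such steps. Both changes therefore carry from one core to the other without a difference that stands out from the scatter, but since every step here lies within the scatter, this does not show that either change has any real effect on the read-out, or that the two add up.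

The compounds shown leave open whether a phenyl ring in place of the furan, or an amine or a longer chain in place of the group on the carbonyl carbon, would give a step beyond the scatter. They also leave open whether the agreement between cores would hold for such a larger step.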